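A few compounds are considered here, and "the series" means these few. Any claim that something is new, unique, unknown or untested is made for them only; others in the source may bear on it.

The series shares one core; the measured compounds differ at the aryl urea end and at the nitrogen on the aromatic ring. Compound 1 `O=C(Nc1ccc(-n2ccc3c(NC(=O)c4ccccc4)ncnc32)cc1)Nc1ccc(Cl)c(C(F)(F)F)c1`, compound 2 `Nc1ncnc2c1ccn2-c1ccc(NC(=O)Nc2cc(C(F)(F)F)cc(C(F)(F)F)c2)cc1` and compound 3 `Nc1ncnc2c1ccn2-c1ccc(NC(=O)Nc2ccc(Cl)c(Cl)c2)cc1` have been measured. In a functional assay on A375P cells (Homo sapiens) for antiproliferative activity, read by MTT assay, with a stated time of 24 h (a lower number here means a stronger inhibitor, a higher number a weaker inhibitor), compound 1 gives 4600 nM, compound 2 gives 3000 nM and compound 3 gives 5400 nM. Compound 2 has the lowest of the three numbers, but its gaps to compound 1 and to compound 3 both lie within the scatter, so the three cannot be ordered on this assay.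

Compound 4 `O=C(Nc1ccc(-n2ccc3c(NC(=O)c4ccccc4)ncnc32)cc1)Nc1cc(C(F)(F)F)cc(C(F)(F)F)c1` has not yet been measured in this assay. It differs from compound 2 by benzoyl in place of hydrogen on a nitrogen on an aromatic ring. Going by the values given here, no step between two measured compounds isolates this change. Compound 1, which already carries the benzamido group together with a different urea aryl end, gives 4600 nM in this assay, within the scatter of compound 2, which gives no sign that the benzamido by itself moves the number far in either direction. The step from compound 2 to compound 4 is therefore expected to be small, a 1.3-fold higher number from compound 2 to compound 4 (0.12 log units; within the scatter), with no direction claimed beyond the scatter. Compound 4 is estimated at 4000 nM in this assay, within a range of 1800 nM to 9000 nM.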

Compound 4, half-maximal inhibitory concentration: 9800 nM
Estimate against measurement, compound 4: 2.5-fold (0.39 log units) below; the measured number lies above the stated range.
By their numbers in this assay, from the lowest: compounds 2, 1, 3 and 4 (each within the scatter of the next, the first and the last beyond it).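

In this assay, going by these compounds alone, the pair of compound 2 and compound 4 isolates the change from amino to benzamido, which no earlier pair did, and it gives a 3.3-fold higher number from compound 2 to compound 4 (0.51 log units; beyond the scatter), a modest step but one beyond the scatter. Benzoyl in place of hydrogen on this nitrogen is therefore not neutral with the urea end these two compounds share, a point that compound 1 could not settle, since it differs from compound 2 in two places. Nothing in the data explains the size or direction of this step.

Going by these compounds, the step rests on this single pair, so it remains open whether the same change moves the number to a similar extent with the urea aryl end of compound 1 or of compound 3. Also open, on these data alone, is which part of the benzoyl group goes with the higher number: an acetyl group on the same nitrogen would keep the carbonyl without the aromatic ring, while a benzyl group would keep the ring without the carbonyl.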